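Nitro removal on the propyl core: expected lipophilicity

This account rests on a few compounds, and the source may have more. Where it says the series, first, only, none or still open, it means among the compounds named here.

Compound 1 `O=c1c2ccccc2nc(-c2ccccc2)n1/N=C/c1ccc(Oc2ccc([N+](=O)[O-])cc2)cc1` is the reference; in a physicochemical assay for lipophilicity, in phosphate buffer, measured as octanol-water partition (a higher number here means a more lipophilic compound, a lower number a more polar compound), compound 1 gives 6.12. Compound 2 `O=c1c2ccccc2nc(-c2ccccc2)n1/N=C/c1ccc(Oc2ccccc2)cc1` differs from it by hydrogen in place of nitro on an aromatic carbon, and in this assay compound 2 gives 6.13; the step is a number 0.01 log units higher from compound 1 to compound 2 (within the scatter). Compound 3 `CCCc1nc2ccccc2c(=O)n1/N=C/c1ccc(Oc2ccc([N+](=O)[O-])cc2)cc1` differs from compound 1 in the core by propyl in place of phenyl on an aromatic carbon, and in this assay compound 3 gives 5.18; the step is a number 0.94 log units lower from compound 1 to compound 3 (beyond the scatter). Compound 4 `CCCc1nc2ccccc2c(=O)n1/N=C/c1ccc(Oc2ccccc2)cc1` differs from compound 3 by hydrogen in place of nitro on an aromatic carbon, the same change at the same place as that from compound 1 to compound 2, on the core of compound 3 rather than that of compound 1. The step from compound 3 to compound 4 is expected to be a number 0.01 log units higher from compound 3 to compound 4 (within the scatter), since the earlier step was a number 0.01 log units higher from compound 1 to compound 2 (within the scatter). Compound 4 is therefore estimated at 5.19 in this assay.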

Compound 4, partition coefficient: 5.2
For compound 4 the middle estimate is 0.01 log units below the measured one; the measured number falls inside the stated range.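

In this assay, hydrogen in place of nitro gives a number 0.02 log units higher from compound 3 to compound 4 (within the scatter), and on the core of compound 1 the same change gives a number 0.01 log units higher from compound 1 to compound 2 (within the scatter); both steps are within the scatter, so the change reads the same on these two cores. The propyl-for-phenyl step also repeats with the nitro gone, with a number 0.93 log units lower from compound 2 to compound 4 (beyond the scatter) against a number 0.94 log units lower from compound 1 to compound 3 (beyond the scatter). Within the data shown here, this covers only two cores and one position and is not a general rule for the series, and nothing measured here bears on the reason for the result.

Going by these compounds, whether an amine or a carboxylic acid in place of the nitro would carry across these cores equally well stays open. So does the behaviour of a longer chain in place of propyl.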